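3-Methoxyphenyl for 2,5-Dimethylphenyl on the Ring Nitrogen

This account rests on a few compounds, and the source may have more. Where it says the series, first, only, none or still open, it means among the compounds named here.

Compound 1, `Cc1nc(-c2ccccc2)c(C(=O)N2CCN(c3c(C)cccc3C)CC2)o1`, gives 146 nM in a functional assay on HL-60 cells (Homo sapiens) for inhibition, read by MTT assay, with a stated time of 72 h; on this read-out higher numbers stand for weaker inhibition and lower numbers for stronger inhibition. Compound 2, `Cc1ccc(C)c(N2CCN(C(=O)c3oc(C)nc3-c3ccc(Cl)cc3)CC2)c1`, was reported in this assay as "not active" (no number reported), with no number attached. Compound 3, `Cc1ccc(C)c(N2CCN(C(=O)c3oc(C)nc3-c3ccc(F)cc3)CC2)c1`, gives 358 nM in this assay.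

Of the two compounds with a number, compound 3 has the higher one, and its gap to compound 1 is beyond the usual scatter of this kind of measurement. Compound 2 stands apart, since no number was reported for it.

Compound 4, `COc1cccc(N2CCN(C(=O)c3oc(C)nc3-c3ccc(F)cc3)CC2)c1`, keeps the shared core of compound 3 and changes only one part: 3-methoxyphenyl in place of 2,5-dimethylphenyl on an amine nitrogen in a ring. Within the data shown here, no measured pair in this set shows the effect of such a swap on the ring amine nitrogen; the measured compounds differ elsewhere. The expectation for compound 4 therefore rests on compound 3 alone, and the step of a 1.1-fold higher number from compound 3 to compound 4 (0.05 log units; within the scatter) is expected to stay within the scatter, with no clear direction. Compound 4 is estimated at 400 nM, in a range from 130 nM to 1300 nM.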

Compound 4, half-maximal inhibitory concentration: 112 nM
Compound 4: middle estimate off by 3.6-fold (0.55 log units), on the high side, and the stated range ends above it.
By their numbers in this assay, from the lowest: compounds 4 and 1 (each within the scatter of the next); then compound 3.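

Replacing 2,5-dimethylphenyl with 3-methoxyphenyl on the ring amine nitrogen, with the rest of compound 3 unchanged, gives a 3.2-fold lower number from compound 3 to compound 4 (0.50 log units; beyond the scatter) in this assay, so the group at this position can shift the inhibition read-out, here toward stronger inhibition. Both groups have 8 heavy atoms, while 3-methoxyphenyl has 1 hydrogen-bond acceptor and 2,5-dimethylphenyl has 0, but a single pair cannot show which structural difference matters. Nothing measured here accounts for the step.

From the compounds shown here alone, it remains open whether the methoxy group itself matters or whether the loss of the two methyl groups is enough. Plain phenyl would help separate those two readings, and 3-hydroxyphenyl or 3-aminophenyl on the same nitrogen would show how far this position tolerates other groups.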